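The source may hold more compounds than are shown below. What is called first, only, known or untested is meant among the compounds shown, and "the series" means these compounds.

Compound 1 `C=CC1=C(C(=O)Nc2ccccc2OC)C(c2ccc(F)cc2)OC1` gives > 100000 nM in a functional assay on HeLa cells (Homo sapiens) for cytotoxicity, read by MTT assay, with a stated time of 24 h (on this read-out lower numbers stand for stronger inhibition and higher numbers for weaker inhibition), a limit of the assay.
Compound 2 `C=CC1=C(C(=O)Nc2ccccc2OC)C(c2ccc(OC)cc2)OC1` gives > 100000 nM in this assay, a limit.
Compound 3 `C=CC1=C(C(=O)NCCC)C(c2ccc(Cl)c(Cl)c2)OC1` gives > 100000 nM in this assay, a limit.

Every value shown in this assay is a limit (the limit of > 100000 nM in this assay, at which 3 of the 3 values shown sit), and compound 3 stands at it alongside compound 1 and compound 2. Among the measured compounds shown here, the one step recorded between measured compounds, a step that the two limits leave unreadable from compound 1 to compound 2, cannot be read, both of its ends being limits. Compound 4 `C=CC1=C(C(=O)Nc2ccccc2OC)C(c2ccc(Cl)c(Cl)c2)OC1` differs from compound 3 by 2-methoxyphenyl in place of propyl on an amide-type nitrogen. For the measured compounds named here, no measured step bears directly on this change; the amide substituent entering is the one carried by compound 1 and compound 2, both of which sit at the limit, so nothing on that side has yielded a number either. With all values at the limit and no readable step, the expectation for compound 4 is a further limit, a step that the limit leaves unreadable from compound 3 to compound 4 meaning no change beyond the scatter. Compound 4 is estimated at 200000 nM in this assay, within 100000 nM to 1000000 nM, and is most likely to be reported as a limit.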

Compound 4, half-maximal inhibitory concentration: > 100000 nM
Compound 4: a limit, no number (the forecaster's own chance of this, stated with the estimate: 85%); the middle value lies beyond the limit too.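

The steps from compound 1, compound 2 and compound 3 to compound 4 cannot be read, since all four compounds sit at a limit: the limit of > 100000 nM in this assay, at which 4 of the 4 values shown sit.
The compounds shown leave open whether any substituent on the shared core gives a measurable value in this assay.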